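The source may hold more compounds than are shown below. What is called first, only, known or untested is meant among the compounds shown, and "the series" means these compounds.

Measured so far:
compound 1 `NS(=O)(=O)OC[C@@H]1C[C@@H](n2nnc3c(NCc4ccccc4F)ncnc32)C[C@@H]1O` — 6.11 nM
compound 2 `NS(=O)(=O)OC[C@@H]1C[C@@H](n2nnc3c(Nc4n[nH]c5ccccc45)ncnc32)C[C@@H]1O` — > 10000 nM

In an assay on a protein complex for inhibition of NEDD8 activating enzyme (Homo sapiens), read by HTRF, with a stated time of 2 h, in the presence of a further agent that is not named here (a lower number here means a stronger inhibitor, a higher number a weaker inhibitor), compound 1 gives 6.11 nM. For compound 2 the result is only a limit, > 10000 nM, so compound 2 stands at the limit of > 10000 nM in this assay, at which 1 of the 2 values shown sits, with no number of its own. Among the compounds with values here, the step of an at least 1600-fold higher number from compound 1 to compound 2 (3.21 log units; beyond the scatter) is the only measured step, and it is large. Compound 3 `NS(=O)(=O)OC[C@@H]1C[C@@H](n2nnc3c(Nc4cnc5ccccn45)ncnc32)C[C@@H]1O` differs from compound 2 by a group of 9 heavy atoms (7 carbon, 2 nitrogen; one five-membered aromatic ring with 2 hetero atoms, one six-membered aromatic ring with 1 hetero atom) in place of a group of 9 heavy atoms (7 carbon, 2 nitrogen; one five-membered aromatic ring with 2 hetero atoms, one six-membered aromatic ring of carbon only), on a nitrogen on an aromatic ring. Within the data shown here, no measured step bears on this rearrangement directly; the one step recorded concerns a different change at the same nitrogen. Compound 3 is therefore expected to stay near the limit, with a number no higher from compound 2 to compound 3 (the limit leaves the size open) as the expected step, and an estimate of 10000 nM (range 2000 nM to 50000 nM).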

Compound 3, half-maximal inhibitory concentration: > 10000 nM
Compound 3 gave a limit, no number (the forecaster's own chance of this, stated with the estimate: 65%); the middle value lies on the limit itself.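

In this assay compound 3 also gives only a limit, so the loss at this nitrogen is not confined to the 1H-indazol-3-yl group: the limit of > 10000 nM in this assay, at which 2 of the 3 values shown sit.

Putting the new group in place of 2-fluorobenzyl gives an at least 1600-fold higher number from compound 1 to compound 3 (3.21 log units; beyond the scatter), and this holds for a group with 0 hydrogen-bond donors, where 1H-indazol-3-yl has 1. No step can be read between the two limits, so the rearrangement itself stays unranked.

Open, as far as these compounds go, is whether a plain benzyl or a phenyl group on this nitrogen would give a number, which would separate the role of the fluorine from that of the carbon link in 2-fluorobenzyl.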